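Aroyl Thiosemicarbazides on a Quinazoline Core: Chloro for Methoxy

The source may report more compounds than this note shows. Statements on the series, on what has been measured and on what is new or still open speak of the compounds shown alone.

Two compounds have been measured in a functional assay on CNE-2 cells (Homo sapiens) for cytotoxicity, read by MTT assay, with a stated time of 72 h; on this read-out lower numbers stand for stronger inhibition and higher numbers for weaker inhibition:

compound 1, `COc1ccccc1C(=O)NC(=S)NNc1ncnc2ccccc12`, giving 15700 nM
compound 2, `COc1cc2ncnc(NNC(=S)NC(=O)c3ccc(C)cc3)c2cc1OC`, giving 33300 nM

Of these two numbers, compound 1 gives the lower one; compound 2 sits higher, and the gap lies beyond the usual scatter. The two structures differ in more than one place, so no single step can be read from them.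

Compound 3, `O=C(NC(=S)NNc1ncnc2ccccc12)c1ccc(Cl)cc1`, keeps the core of compound 1 and carries 4-chlorophenyl in place of 2-methoxyphenyl on a carbonyl carbon. Going by the values given here, no measured pair isolates this exchange, so the step has to be judged from compound 1 alone. The change from compound 1 to compound 3 is expected to be small in this assay, with no direction beyond the scatter, that is a 1.1-fold higher number from compound 1 to compound 3 (0.06 log units; within the scatter). Compound 3 is therefore estimated at 18000 nM, with a range from 6000 nM to 55000 nM.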

Compound 3, half-maximal inhibitory concentration: 1530 nM
Compound 3: the middle estimate sits 12-fold (1.07 log units) above what was measured, outside the stated range (below it).
By their numbers in this assay, from the lowest: compound 3; then compound 1; then compound 2.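

In this assay, the exchange of 2-methoxyphenyl for 4-chlorophenyl on a carbonyl carbon gives a 10-fold lower number from compound 1 to compound 3 (1.01 log units; beyond the scatter) on an unchanged core. Compound 1 and compound 2 differed in more than one place and could say nothing about this position alone, whereas this pair shows that the aryl group on the carbonyl carbon can by itself produce a large change in inhibition. Nothing in the data at hand accounts for the size of this step.

Since one whole group replaces another, the compounds shown leave open how far the gain depends on the chlorine arriving or on the methoxy leaving. They also leave open where a plain phenyl, or a phenyl carrying bromine or an amine, would fall on this read-out, and whether the exchange holds on the core of compound 2.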